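Chain-terminal nitrile to thioether in the acetophenone series

The compounds below may be only part of what the source reports. "The series", "measured", "known", "first", "only" and "open" are said of these compounds alone.

Measured so far:
Compound 1 `CC(=O)c1cc(C(C)=O)c(OCCCCC#N)cc1O` gives 0% in an assay on isolated protein for binding affinity to leukotriene B4 receptor 1 (Homo sapiens), tested at 1 uM; a higher number here means more inhibition at the concentration tested (going by the name of the read-out), a lower number less inhibition.
Compound 2 `C=CCc1cc(C(C)=O)c(O)cc1OCCCCCCCCCCC#N` gives 14% in this assay.
Compound 3 `CCc1cc(C(C)=O)c(O)cc1OCCCC(C)(C)C#N` gives 46% in this assay.

Compound 3 stands highest of the three numbers; its nearest neighbour is compound 2, a number beyond the scatter below it, and compound 1 lies furthest below, also beyond the scatter.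

Compound 4 `CCc1cc(C(C)=O)c(O)cc1OCCCCCCSC` is not yet measured. It differs from compound 3 in one place: 3-(methylsulfanyl)propyl in place of 1-cyano-1-methylethyl on a saturated chain carbon, three bonds along the chain from an oxygen on an aromatic ring. Within the data shown here, no step between measured compounds isolates this kind of change, so the direction is uncertain. The step from compound 3 to compound 4 in this assay is expected to be downward and modest, a number 16 percentage points lower from compound 3 to compound 4 (beyond the scatter). Compound 4 is estimated at 30%, within a range from 5% to 60%.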

Compound 4, a percentage reported as inhibition, at one concentration (the size of the read-out at that concentration, not a potency): 14%
Compound 4: middle estimate off by 16 percentage points, on the high side, within the range that was stated.
By their numbers in this assay, from the lowest: compound 1; then compounds 2 and 4 (each within the scatter of the next); then compound 3.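

Among these compounds, the change reads as a number 32 percentage points lower from compound 3 to compound 4 (beyond the scatter) in this assay, the first comparison that isolates one place. On a saturated chain carbon, three bonds along the chain from an oxygen on an aromatic ring, groups with matching counts of heavy atoms and hydrogen-bond acceptors therefore do not give matching numbers. Nothing available gives a reason for this step. Still open, on these data alone, is whether the nitrile or the methyl branching of 1-cyano-1-methylethyl carries the difference, as the two leave together. An unbranched 3-cyanopropyl or a tert-butyl group in the same place would separate them.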